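The source may report more compounds than this note shows. Statements on the series, on what has been measured and on what is new or still open speak of the compounds shown alone.

Measured in a functional assay on DU-145 cells (Homo sapiens) for inhibition, read by trypan blue exclusion, with a stated time of 96 h; on this read-out lower numbers stand for stronger inhibition of growth and higher numbers for weaker inhibition of growth:

- Compound 1 `CSc1ccc(/C=C(\C(=O)c2ccc(Cl)cc2)S(=O)(=O)Cc2ccc(C)cc2)cc1`: 10000 nM
- Compound 2 `COc1ccccc1/C=C(\C(=O)c1ccc(Cl)cc1)S(=O)(=O)Cc1ccc(C)cc1`: 10000 nM

Level with compound 1, compound 2 `COc1ccccc1/C=C(\C(=O)c1ccc(Cl)cc1)S(=O)(=O)Cc1ccc(C)cc1` stands at 10000 nM. Compound 3 `Cc1ccc(CS(=O)(=O)/C(=C/c2sccc2C)C(=O)c2ccc(Cl)cc2)cc1` is not yet measured. It carries 3-methylthiophen-2-yl in place of 2-methoxyphenyl on a double-bonded chain carbon bound to a double-bonded chain carbon.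

Among the compounds with values here, only one measured step bears on this change, an exchange at the same place. That step, no change at the digits printed from compound 1 to compound 2 (within the scatter), lies within the scatter. It is a single step and the new group has not been tested in this series, so the evidence is thin. On this basis, no step beyond the scatter is expected in this assay. The estimated step is no change at the digits printed from compound 2 to compound 3 (within the scatter). For compound 3 the estimated value is 10000 nM, with an expected range from 3000 nM to 20000 nM.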

Compound 3, concentration for 50% growth inhibition: 25000 nM
For compound 3 the middle estimate is 2.5-fold (0.40 log units) below the measured one; measured number outside the range, above it.
By their numbers in this assay, from the lowest: compounds 1 and 2 (each within the scatter of the next); then compound 3.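

At this position, this assay had so far shown only an exchange between two substituted phenyl groups, which left the number unmoved. With 3-methylthiophen-2-yl, a five-membered aromatic ring with one hetero atom in place of a six-membered ring of carbon only, the read-out shows a modest loss of growth inhibition beyond the scatter, both against the 2-methoxyphenyl group (a 2.5-fold higher number from compound 2 to compound 3 (0.40 log units; beyond the scatter)) and against the 4-(methylsulfanyl)phenyl group (a 2.5-fold higher number from compound 1 to compound 3 (0.40 log units; beyond the scatter)). Nothing measured on these compounds accounts for this loss.

The compounds shown do not separate the part played by the ring from that of its methyl group, as the plain thiophen-2-yl group does not appear among them. They also leave open how this position would respond to a pyridine ring or to a phenyl group carrying an amine.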